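Swapping the dimethoxyphenyl ring for a pyridine ring

The source may report more compounds than this note shows. Statements on the series, on what has been measured and on what is new or still open speak of the compounds shown alone.

Three compounds share one core and differ only in the ring carried on a carbon with a double bond to nitrogen. In a functional assay on the whole organism (strain Wistar) for inhibition, with Rattus norvegicus as the target, read by paw edema, with a stated time of 1 h, at a dose of 10 mg/kg by the intraperitoneal route (on this read-out higher numbers stand for more inhibition at the one dose given (going by the name of the read-out) and lower numbers for less inhibition), compound 1 `O=C(N/N=C/c1cccc(F)c1)c1cccnc1Nc1cccc(C(F)(F)F)c1` gives 51.5%, compound 2 `COc1ccc(/C=N/NC(=O)c2cccnc2Nc2cccc(C(F)(F)F)c2)c(OC)c1` gives 55.7%, and compound 3 `COc1ccc(/C=N/NC(=O)c2cccnc2Nc2cccc(C(F)(F)F)c2)cc1OC` gives 70%, the highest of the three: a number 18.5 percentage points higher from compound 1 to compound 3 (beyond the scatter) and a number 14.3 percentage points higher from compound 2 to compound 3 (beyond the scatter), whereas a number 4.2 percentage points higher from compound 1 to compound 2 (within the scatter). Compound 4 `O=C(N/N=C/c1cccnc1)c1cccnc1Nc1cccc(C(F)(F)F)c1` carries the change (pyridin-3-yl in place of 3,4-dimethoxyphenyl on a carbon with a double bond to nitrogen). Among the compounds with values here, no measured step involves a pyridin-3-yl ring at this place; the two steps that do bear on it show that exchanging the ring there shifts the read-out by modest amounts, and compound 3 already holds the top value. A modest fall is therefore the expected step, a number 15 percentage points lower from compound 3 to compound 4 (beyond the scatter). Compound 4 is accordingly estimated at 55%, with a range from 40% to 70%.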

Compound 4, a percentage reported as inhibition, in the whole organism at one dose (the size of the read-out at that dose, not a potency): 76.1%
Beside the measured number, compound 4's estimate is 21.1 percentage points below it; measured number above the stated range.
By their numbers in this assay, from the lowest: compounds 1 and 2 (each within the scatter of the next); then compounds 3 and 4 (each within the scatter of the next).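

In this assay, the methoxy groups of compound 3 turn out not to be needed on the carbon with a double bond to nitrogen: a plain pyridin-3-yl ring, with fewer heavy atoms, reads level with 3,4-dimethoxyphenyl (a number 6.1 percentage points higher from compound 3 to compound 4 (within the scatter)). The same ring stands clear of the other two (a number 20.4 percentage points higher from compound 2 to compound 4 (beyond the scatter); a number 24.6 percentage points higher from compound 1 to compound 4 (beyond the scatter)). Nothing measured here explains these differences. Still open, on these data alone, is how a pyridin-4-yl ring, or a pyridin-3-yl ring carrying an amine, would read at this place.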